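Dropping the Vinyloxy Group from a Bromopyridine Efficacy Series

The compounds below may be only part of what the source reports. "The series", "measured", "known", "first", "only" and "open" are said of these compounds alone.

Of the compounds shown here, three have been measured in an assay on HEK293 cells with Neuronal acetylcholine receptor; alpha4/beta2 (Homo sapiens) as the target, read by FLIPR and calcium flux; a lower number here means a smaller maximal response, a higher number a larger maximal response. Compound 1 `Clc1cncc(N2CCCNCCC2)c1` gives 103%, the highest of the three numbers. Compound 2 `COc1cncc(N2CCCNCC2)c1` gives 66%, the lowest. Compound 3 `C=COc1cc(N2CCCNCCC2)cnc1Br` gives 90%, which places it second of the three; its nearest neighbour is compound 1, sitting higher by a margin beyond the usual scatter, and its furthest is compound 2, sitting lower by a margin also beyond the scatter.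

The next compound to be measured is compound 4 `Brc1ccc(N2CCCNCCC2)cn1`. It differs from compound 3 in a single place: hydrogen in place of vinyloxy on an aromatic carbon. Within the data shown here, no pair of measured compounds differing in only one place exists here, so there is no measured step to lean on for the size of this change.

The expectation is therefore a small upward shift in this assay, of a size that may not exceed the scatter, since compound 3 already sits at 90% and compound 1 shows that values near 103% are reachable in this set. The step from compound 3 to compound 4 is estimated as a number 8 percentage points higher from compound 3 to compound 4 (within the scatter). Compound 4 is expected to give about 98%, with a plausible range from 80% to 115%.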

Compound 4, largest response reached (reported as efficacy), in percent of the reference or control that the assay uses: 139%
Compound 4: middle estimate off by 41 percentage points, on the low side, and the stated range ends below it.
By their numbers in this assay, from the lowest: compound 2; then compound 3; then compound 1; then compound 4.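

In this assay, among these compounds, replacing the vinyloxy group with hydrogen on this aromatic carbon gives a number 49 percentage points higher from compound 3 to compound 4 (beyond the scatter), the first measured step in this set between two compounds that differ in only one place. The change shows that this position, ortho to a bromo group and two atoms from the ring nitrogen, has a strong bearing on the maximal response, and that the vinyloxy group is not needed for a high one: compound 4 reaches 139% with only hydrogen there. Nothing measured here explains why the response rises when this group is removed.

With a single step at a single position, it remains unclear whether any group at this carbon would lower the response or whether the effect is particular to vinyloxy, and an ethoxy group, a methyl group or an amine at the same place would help separate those possibilities. It is also unclear how much the bromo group contributes to the response of compound 4, since no pair shown changes that group alone.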